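Trifluoromethyl to cyanomethyl on the chain: working notes

A few compounds are considered here, and "the series" means these few. Any claim that something is new, unique, unknown or untested is made for them only; others in the source may bear on it.

In a toxicity assay on HT-29 cells (Homo sapiens) for cytotoxicity (on this read-out lower numbers stand for higher toxicity in this test and higher numbers for lower toxicity in this test), compound 2 `CN1C(=S)[C@@H](NC(=O)c2nc(Cc3ccccc3)n(CCC(F)(F)F)n2)COc2ccccc21` gives > 100000 nM as a limit of the assay and not a number. Compound 1 `CCn1nc(C(=O)N[C@H]2COc3ccccc3N(C)C2=S)nc1Cc1ccccc1` gives > 100000 nM in this assay and this too is only a limit. Neither compound therefore has a measured value to build on.

Compound 3 `CN1C(=S)[C@@H](NC(=O)c2nc(Cc3ccccc3)n(CCCC#N)n2)COc2ccccc21` carries cyanomethyl in place of trifluoromethyl on a saturated chain carbon, two bonds along the chain from an aromatic nitrogen. The difference cyanomethyl in place of trifluoromethyl on a saturated chain carbon, two bonds along the chain from an aromatic nitrogen turns 3,3,3-trifluoropropyl into 3-cyanopropyl on the shared core.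

Going by the values given here, one measured step bears on this place: a step that the two limits leave unreadable from compound 1 to compound 2 with trifluoromethyl in place of hydrogen on that carbon. Its size cannot be read, as both ends are limits. Among the compounds with values here, the series so far offers only the limit of > 100000 nM in this assay, at which 2 of the 2 values shown sit, as its evidence.

No step beyond the scatter is expected in this assay and no direction can be given. The expected step is a number no higher from compound 2 to compound 3 (the limit leaves the size open) on this estimate. For compound 3 the estimated value is 100000 nM with an expected range of 50000 nM to 200000 nM and a report as a limit is the likeliest outcome.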

Compound 3, half-maximal cytotoxic concentration: > 100000 nM
Compound 3: no number, only a limit (the forecaster's own chance of this, stated with the estimate: 85%); the middle value sits exactly at the limit.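

In this assay compound 3 gives > 100000 nM, which is a limit of the assay and not a number. Going by these compounds alone, compound 1 and compound 2 are also reported only as limits, so no step among the three compounds can be read. The compounds shown leave open whether hydrogen, trifluoromethyl or cyanomethyl at this place makes any difference to the read-out.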